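From Pentyl to Dimethoxyphenyl on a Capsaicin-Type Antagonist

A few compounds are considered here, and "the series" means these few. Any claim that something is new, unique, unknown or untested is made for them only; others in the source may bear on it.

Measured compounds:
compound 1 `CCCOc1cc(C(F)(F)F)ccc1CNC(=O)C(C)c1ccc(NS(C)(=O)=O)c(F)c1`: 2 nM
compound 2 `CCCCCc1cc(C(F)(F)F)ccc1CNC(=O)C(C)c1ccc(NS(C)(=O)=O)c(F)c1`: 0.4 nM

In an assay on CHO cells for antagonist activity at transient receptor potential cation channel subfamily V member 1 (Homo sapiens), read by FLIPR (a lower number here means a stronger inhibitor, a higher number a weaker inhibitor), compound 2 gives 0.4 nM, the lowest of the two numbers at hand; its nearest neighbour is compound 1, which in this assay gives 2 nM. Going by the values given here, the single step between them, a 5.0-fold lower number from compound 1 to compound 2 (0.70 log units; beyond the scatter), is beyond the scatter. Compound 3 `COc1ccc(-c2cc(C(F)(F)F)ccc2CNC(=O)C(C)c2ccc(NS(C)(=O)=O)c(F)c2)cc1OC` is not yet measured in this assay. It differs from compound 2 by one change: 3,4-dimethoxyphenyl in place of pentyl on an aromatic carbon. Among the compounds with values here, the only measured step bears on it loosely, since it also changes the group at this same aromatic carbon, but it swaps one chain for another, not a chain for a ring. The new group carries two acceptors and a further ring where compound 2 carries a plain chain, so a step back upward seems more likely than a further gain. Compound 3 is therefore expected near 2 nM, in the range 0.3 nM to 15 nM, which would mean an estimated 5.0-fold higher number from compound 2 to compound 3 (0.70 log units; beyond the scatter).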

Compound 3, inhibition constant: 8.6 nM
The estimate for compound 3 lay 4.3-fold (0.63 log units) below the measured number, and the stated range covers the measured number.
By their numbers in this assay, from the lowest: compound 2; then compound 1; then compound 3.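

In this assay, going by these compounds alone, the aromatic carbon ortho to a large group, until now seen only with chains, also accepts a ring: compound 3, with 3,4-dimethoxyphenyl there, still gives a low number (8.6 nM). The ring does, however, lose ground against both chains (a 22-fold higher number from compound 2 to compound 3 (1.33 log units; beyond the scatter); a 4.3-fold higher number from compound 1 to compound 3 (0.63 log units; beyond the scatter)), so that pentyl gives the lowest number of the three groups and 3,4-dimethoxyphenyl the highest. No measurement at hand explains this order.

The compounds shown do not separate the contribution of the ring from that of its two methoxy groups, which unsubstituted phenyl or 4-methoxyphenyl at this carbon would address. They also leave open how far the chain series extends, whether through a longer chain such as heptyl or through a chain ending in an amine.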